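From acetyl to difluoromethyl on a shared core

The source may hold more compounds than are shown below. What is called first, only, known or untested is meant among the compounds shown, and "the series" means these compounds.

Measured so far in a physicochemical assay for solubility, read by chemiluminescence, measured as kinetic solubility; on this read-out higher numbers stand for higher solubility and lower numbers for lower solubility:

Compound 1 `CC(=O)NCc1cccc(Cn2nc(NS(=O)(=O)c3ccc(Cl)s3)c3c(C#N)cccc32)c1`: >= 155 ug/mL (a limit of the assay)
Compound 2 `CC(=O)NCc1cccc(Cn2nc(NS(=O)(=O)c3ccc(Cl)s3)c3c(C(C)=O)cccc32)c1`: 57 ug/mL

In this assay, within the data shown here, compound 2 gives 57 ug/mL, the only true number so far. Compound 1 reports only a limit, >= 155 ug/mL. The next compound, compound 3 `CC(=O)NCc1cccc(Cn2nc(NS(=O)(=O)c3ccc(Cl)s3)c3c(C(F)F)cccc32)c1`, has difluoromethyl in place of acetyl on an aromatic carbon, (difluoromethyl in place of acetyl on an aromatic carbon).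

Among the measured compounds shown here, one measured step bears on this change, and it concerns the same aromatic carbon. With acetyl in place of cyano, the record shows an at least 2.7-fold lower number from compound 1 to compound 2 (0.43 log units; beyond the scatter). That step starts from a limit and does not involve difluoromethyl, so it gives only a loose guide to the size of the next step and none to its direction. A modest change is therefore expected, with a slight lean towards lower numbers and no firm claim that it will clear the usual scatter. The expected step is a 1.4-fold lower number from compound 2 to compound 3 (0.15 log units; within the scatter). For compound 3 the estimated value is 40 ug/mL, with an expected range from 12 ug/mL to 125 ug/mL.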

Compound 3, solubility: >= 188 ug/mL
Compound 3: no number, only a limit (the forecaster's own chance of this, stated with the estimate: 10%); middle value at least 4.7-fold (0.67 log units) from the limit.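

In this assay, replacing acetyl with difluoromethyl on this aromatic carbon gives an at least 3.2-fold higher number from compound 2 to compound 3 (0.51 log units; beyond the scatter). Compound 3 gives >= 188 ug/mL, which is a limit of the assay and not a number. Read together with the earlier at least 2.7-fold lower number from compound 1 to compound 2 (0.43 log units; beyond the scatter), this shows that the position can move the read-out in either direction, and that acetyl sits lower than both cyano and difluoromethyl, with each of the two steps beyond the usual scatter.

The step between compound 1 and compound 3 cannot be read, since both values are limits, so cyano and difluoromethyl remain unordered with respect to each other. Also open, from the compounds shown here alone, is where an amine or a carboxylic acid on this aromatic carbon would fall, and whether the lower reading belongs to acetyl alone or also to another carbonyl group, such as a methyl ester.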